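Replacing the 4-bromophenyl group on the amide nitrogen

This account rests on a few compounds, and the source may have more. Where it says the series, first, only, none or still open, it means among the compounds named here.

Values in an ADME assay on MT4 cells (Homo sapiens) for cytotoxicity, read by MTT assay, with a stated time of 5 days; on this read-out lower numbers stand for higher toxicity in this test and higher numbers for lower toxicity in this test:
compound 1 `Cc1cnc(Nc2ccc(C#N)cc2)nc1OCC(=O)Nc1ccc(F)cc1`: > 331000 nM (a limit)
compound 2 `Cc1cnc(Nc2ccc(C#N)cc2)nc1OCC(=O)Nc1ccc(Cl)cc1`: > 317000 nM (a limit)
compound 3 `Cc1cnc(Nc2ccc(C#N)cc2)nc1OCC(=O)Nc1ccc(Br)cc1`: 34700 nM

For the measured compounds named here, compound 3 stands at 34700 nM, the only actual number in the set. The other two values are limits. Compound 4 `Cc1cnc(Nc2ccc(C#N)cc2)nc1OCC(=O)Nc1ccc(C#N)cc1F`, not yet measured, differs from it in one place: 4-cyano-2-fluorophenyl in place of 4-bromophenyl on an amide-type nitrogen.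

Going by the values given here, two measured steps bear on this change, an at least 9.5-fold lower number from compound 1 to compound 3 (0.97 log units; beyond the scatter) and an at least 9.1-fold lower number from compound 2 to compound 3 (0.96 log units; beyond the scatter). Both are beyond the scatter and both end at the bromo compound. The third, a step that the two limits leave unreadable from compound 1 to compound 2, cannot be read. Among the compounds with values here, no measured compound carries the 4-cyano-2-fluorophenyl group, so these steps transfer only loosely. With the bromo gone, a modest move to a higher number is expected in this assay, meaning lower toxicity in this test, and the result may be only a limit. The expected change is a 3.2-fold higher number from compound 3 to compound 4 (0.50 log units; beyond the scatter). The estimate for compound 4 is 110000 nM, with an expected range of 25000 nM to 330000 nM.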

Compound 4, half-maximal cytotoxic concentration: > 310000 nM
Compound 4: a limit, no number; the forecaster's own chance of this, stated with the estimate: 40%; middle value at least 2.8-fold (0.44 log units) from the limit.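

In this assay compound 4 gives a limit and not a number: the limit of > 310000 nM in this assay, at which 1 of the 4 values shown sits.

The change gives an at least 8.9-fold higher number from compound 3 to compound 4 (0.95 log units; beyond the scatter), so the lower number does not carry over to this position once 4-cyano-2-fluorophenyl replaces 4-bromophenyl on the amide-type nitrogen. Among the four compounds, compound 3 alone has a measured number, and the steps among compound 1, compound 2 and compound 4 cannot be read, as all three values are limits.

The change swaps the bromine for both a nitrile and a fluorine, so the compounds shown cannot separate the part played by each. An iodophenyl group, an unsubstituted phenyl group or a cyanophenyl group without the fluorine on the amide-type nitrogen would test whether the lower number belongs to the bromo compound alone.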